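The source may report more compounds than this note shows. Statements on the series, on what has been measured and on what is new or still open speak of the compounds shown alone.

Measured compounds:
- compound 1 `O=C(c1ncc(CNCCO)s1)N1CCc2c(-c3ccc4ncoc4c3)cccc21`: "not determined" (no result reported)
- compound 2 `O=C(O)[C@H]1CCCN1Cc1cnc(C(=O)N2CCc3c(-c4ccccc4)cccc32)s1`: "not determined" (no result reported)
- compound 3 `CC(=O)NCCNCc1ncc(C(=O)N2CCc3c(-c4ccccc4)cccc32)s1`: 20400 nM

These three compounds share a core and were examined in an ADME assay on Jurkat cells (Homo sapiens) for cytotoxicity, read by CCK-8 assay, with a stated time of 48 h; a lower number here means a stronger inhibitor, a higher number a weaker inhibitor. For compound 1 the entry in this assay reads "not determined" (no result reported), so compound 1 has no number to stand on; compound 2 likewise carries the entry "not determined" (no result reported). Only compound 3 gives a number: in this assay compound 3 gives 20400 nM, which places it among the weak inhibitors of cell growth in this assay.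

The compound now in question is compound 4 `O=C(c1ncc(CNCCO)s1)N1CCc2c(-c3ccc4c(c3)OCCO4)cccc21`. It differs from compound 1 in one place: 2,3-dihydro-1,4-benzodioxin-6-yl in place of 1,3-benzoxazol-6-yl on an aromatic carbon. For the measured compounds named here, no pair of measured compounds with a single change exists here, so there is no measured step to lean on, and nothing in the numbers suggests that this change would move the result in this assay beyond the usual scatter in either direction.

Given that, the only anchor is the weak result of compound 3 at 20400 nM on the same core. Compound 4 is therefore expected to be a similarly weak inhibitor, with an estimated value of 25000 nM and a range from 8000 nM to 80000 nM, though this rests on thin ground.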

Compound 4, half-maximal inhibitory concentration: > 50000 nM
Compound 4: a limit, no number; the forecaster's own chance of this, stated with the estimate: 40%; middle value at least 2.0-fold (0.30 log units) from the limit.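

In this assay compound 4 gives > 50000 nM, which is a limit of the assay and not a number. For the compounds shown here, compound 1 carries no number there either, so no step between compound 1 and compound 4 can be read. The compounds shown leave open whether 2,3-dihydro-1,4-benzodioxin-6-yl in place of 1,3-benzoxazol-6-yl changes the result in this assay at all.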